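The compounds below may be only part of what the source reports. "The series", "measured", "known", "first", "only" and "open" are said of these compounds alone.

Working notes on the series. Compound 3 `Cc1cc(-c2c(C)nn(-c3nc(-c4ccc(Cl)c(Cl)c4)c(SC(C)C)s3)c2C(=O)O)cc(C)n1` gives the lowest number of the three measured compounds in a functional assay on BJAB cells (Homo sapiens) for antiproliferative activity, with a stated time of 4 days (on this read-out lower numbers stand for an effect already at smaller amounts and higher numbers for an effect only at larger amounts of compound), at 580 nM. Compound 1 `COc1cc(-c2c(C)nn(-c3nc(-c4ccc(Cl)c(Cl)c4)c(SC(C)C)s3)c2C(=O)O)cc(C(F)(F)F)c1` gives 1380 nM in this assay and compound 2 `Cc1nn(-c2nc(-c3ccc(Cl)c(Cl)c3)c(SC(C)C)s2)c(C(=O)O)c1-c1cnn(C)c1` gives 6800 nM. Compound 4 `Cc1nn(-c2nc(-c3ccc(Cl)c(Cl)c3)c(SC(C)C)s2)c(C(=O)O)c1-c1ccc(C(F)(F)F)cc1` differs from compound 3 by the change (4-(trifluoromethyl)phenyl in place of 2,6-dimethylpyridin-4-yl on an aromatic carbon). The same position was changed in a 2.4-fold lower number from compound 1 to compound 3 (0.38 log units; beyond the scatter) and in a 12-fold lower number from compound 2 to compound 3 (1.07 log units; beyond the scatter), both moving toward compound 3. Since the incoming group lacks the ring nitrogen of compound 3 and carries a trifluoromethyl like compound 1, a modest step upward is expected in this assay, roughly a 2.1-fold higher number from compound 3 to compound 4 (0.32 log units; beyond the scatter). Compound 4 is therefore estimated at 1200 nM, with a range from 500 nM to 3000 nM.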

Compound 4, half-maximal effective concentration: 3500 nM
Compound 4: middle estimate off by 2.9-fold (0.46 log units), on the low side, and the stated range ends below it.
By their numbers in this assay, from the lowest: compound 3; then compound 1; then compounds 4 and 2 (each within the scatter of the next).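

In this assay, 4-(trifluoromethyl)phenyl in place of 2,6-dimethylpyridin-4-yl costs more than the first estimate allowed (a 6.0-fold higher number from compound 3 to compound 4 (0.78 log units; beyond the scatter)), and compound 3 keeps the lowest number of the four. The two trifluoromethyl-bearing phenyl groups are not interchangeable here (a 2.5-fold higher number from compound 1 to compound 4 (0.40 log units; beyond the scatter)). 4-(Trifluoromethyl)phenyl and 1-methyl-1H-pyrazol-4-yl are not separated (a 1.9-fold lower number from compound 2 to compound 4 (0.29 log units; within the scatter)). No measurement at hand explains these differences. As far as these compounds go, whether the ring nitrogen or the two methyl groups of compound 3 matter stays open, and pyridin-4-yl without methyl groups or plain phenyl would bear on this.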